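Adding a Methyl to the Sulfonyl Aryl Ring

The compounds below may be only part of what the source reports. "The series", "measured", "known", "first", "only" and "open" are said of these compounds alone.

Compound 3 `O=S(=O)(c1cccc(F)c1)c1cnc2c(F)cccc2c1-c1cccc(Cl)c1` gives 0.56 mL/min in an ADME assay on microsomes from liver (Homo sapiens) for metabolic stability, tested at 2.5 uM (on this read-out lower numbers stand for slow clearance and higher numbers for fast clearance), the lowest of the three numbers measured. Compound 1 `O=S(=O)(c1ccc(F)cc1)c1cnc2c(F)cccc2c1-c1cccc(Cl)c1` gives 1.21 mL/min in this assay, and the step of a 2.2-fold lower number from compound 1 to compound 3 (0.33 log units; beyond the scatter). Compound 2 `COc1cccc(-c2c(S(=O)(=O)c3ccc(C)c(F)c3)cnc3c(F)cccc23)c1` gives 4.02 mL/min in this assay, the highest of the three.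

Compound 4 `Cc1ccc(S(=O)(=O)c2cnc3c(F)cccc3c2-c2cccc(Cl)c2)cc1F` has not yet been measured. It differs from compound 3 in one place: methyl in place of hydrogen on an aromatic carbon. Cut one bond further out, the change reads 3-fluorophenyl to 3-fluoro-4-methylphenyl on the sulfonyl sulfur.

Within the data shown here, no measured step concerns a methyl in place of hydrogen; the only step, a 2.2-fold lower number from compound 1 to compound 3 (0.33 log units; beyond the scatter), concerns where the fluoro group sits on the same ring. Compound 2 carries the same 3-fluoro-4-methylphenyl on the sulfonyl sulfur and gives 4.02 mL/min, but it also differs from compound 4 in the aryl group on the core, so its number shows only that this sulfonyl aryl can sit in a compound with a high reading.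

Among the measured compounds shown here, with that as the only guide, the account expects a rise, modest to clear, so that a 2.7-fold higher number from compound 3 to compound 4 (0.43 log units; beyond the scatter) is the estimated step. Compound 4 is therefore expected to give about 1.5 mL/min in this assay, within a range from 0.6 mL/min to 4 mL/min.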

Compound 4, intrinsic clearance in a liver preparation (reported as CLH), per the amount of preparation that the assay uses: 3.18 mL/min
Estimate against measurement, compound 4: 2.1-fold (0.33 log units) below, and the stated range covers the measured number.
By their numbers in this assay, from the lowest: compound 3; then compound 1; then compounds 4 and 2 (each within the scatter of the next).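

In this assay, among these compounds, the methyl on the aromatic carbon ortho to a fluoro group gives the first reading of a change of this kind, and the step is a 5.7-fold higher number from compound 3 to compound 4 (0.75 log units; beyond the scatter) on the sulfonyl aryl ring, larger in size than the one that came from shifting the fluoro group, a 2.2-fold lower number from compound 1 to compound 3 (0.33 log units; beyond the scatter) on that same ring. The low number of compound 3 is therefore not kept once the methyl enters: against the 4-fluorophenyl group, 3-fluoro-4-methylphenyl gives a 2.6-fold higher number from compound 1 to compound 4 (0.42 log units; beyond the scatter) and, with this sulfonyl aryl held, chloro in place of methoxy gives a 1.3-fold lower number from compound 2 to compound 4 (0.10 log units; within the scatter) so that the aryl group on the core does not separate these two compounds in this assay here. Nothing in the material shown gives a reason for the rise from the methyl.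

The compounds shown leave open whether the rise is particular to the methyl, or whether an ethyl, a methoxy or a chloro on the same aromatic carbon would give a similar number. They also leave open whether the methyl has the same effect on this number when the methoxy-bearing aryl group of compound 2 sits on the core.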